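Trifluoromethyl in Place of Chloro on the Urea Aryl Ring

A few compounds are considered here, and "the series" means these few. Any claim that something is new, unique, unknown or untested is made for them only; others in the source may bear on it.

Compound 1, `O=C(Nc1cccc(-n2cc(-c3ccncc3)c(-c3ccc(Cl)c(O)c3)n2)c1)Nc1ccc(Cl)c(Cl)c1`: 1110 nM
Compound 2, `O=C(Nc1cccc(-n2cc(-c3ccncc3)c(-c3ccc(Cl)c(O)c3)n2)c1)Nc1cc(C(F)(F)F)cc(C(F)(F)F)c1`: 749 nM

Both compounds were measured in a functional assay on UACC-62 cells (Homo sapiens) for inhibition, read by sulforhodamine B assay, with a stated time of 48 h; a lower number here means a stronger inhibitor of growth, a higher number a weaker inhibitor of growth. On these two numbers compound 1 sits within the scatter of compound 2, so neither can be called the stronger or the weaker growth inhibitor. Compound 3, `O=C(Nc1cccc(-n2cc(-c3ccncc3)c(-c3ccc(Cl)c(O)c3)n2)c1)Nc1ccc(Cl)c(C(F)(F)F)c1`, is not yet measured. It differs from compound 1 in one place: trifluoromethyl in place of chloro on an aromatic carbon. Among the measured compounds shown here, no measured pair shows this change directly, so the expected step is a 1.2-fold lower number from compound 1 to compound 3 (0.09 log units; within the scatter), no larger than the scatter. Compound 3 is therefore estimated at 900 nM, with a range from 400 nM to 2000 nM.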

Compound 3, concentration for 50% growth inhibition: 627 nM
For compound 3 the middle estimate is 1.4-fold (0.16 log units) above the measured one, and the stated range covers the measured number.
By their numbers in this assay, from the lowest: compounds 3, 2 and 1 (each within the scatter of the next).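

In this assay, the change from 3,4-dichlorophenyl to 4-chloro-3-(trifluoromethyl)phenyl can now be read directly, as a 1.8-fold lower number from compound 1 to compound 3 (0.25 log units; within the scatter) in a single swap. This position therefore accepts trifluoromethyl, with 4 heavy atoms, in place of chloro, with 1 heavy atom, without a shift that clears the scatter. No separate measurement bears on this result.

Going by these compounds, whether an amine, a carboxylic acid or a methoxy group at this position would move the number beyond the scatter remains open. So does whether the same swap would read alike on a different core.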